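The source may hold more compounds than are shown below. What is called first, only, known or untested is meant among the compounds shown, and "the series" means these compounds.

The measured compounds are compound 1 `COc1ccc(Sc2ccccc2N2CC(C)N(CC(=O)O)CC2C)cc1` with 580 nM and compound 2 `COc1ccc(Sc2ccccc2N2C[C@@H](C)N(CC(=O)O)C[C@H]2C)cc1` with 16000 nM.

In an assay for inhibition of sodium- and chloride-dependent glycine transporter 1 (Homo sapiens) (a higher number here means a weaker inhibitor, a lower number a stronger inhibitor), compound 1 stands lowest of the two numbers; its nearest neighbour is compound 2, reached by a 28-fold higher number from compound 1 to compound 2 (1.44 log units; beyond the scatter). That step changes no atom or bond; the two structures are distinguished only by how the two ring stereocentres are drawn (the fact that one of compounds 1 and 2 is drawn with a defined configuration and the other without, at the place where they differ), compound 1 without configuration and compound 2 as R at both.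

Compound 3 `COc1ccc(Sc2ccccc2N2CCN(CC(=O)O)C(C)C2)cc1` is reached from compound 1 by hydrogen in place of methyl on a saturated ring carbon. For the measured compounds named here, the single measured step does not touch a methyl group, so it offers no direct guide to this change. Removal of one methyl from the shared core is a small alteration, and a step near or within the scatter is expected, if anything towards a somewhat higher number. Compound 3 is therefore estimated at 1000 nM, with a range from 300 nM to 4000 nM, meaning an expected step of a 1.7-fold higher number from compound 1 to compound 3 (0.24 log units; within the scatter).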

Compound 3, half-maximal inhibitory concentration: 1700 nM
Estimate against measurement, compound 3: 1.7-fold (0.23 log units) below, within the range that was stated.
By their numbers in this assay, from the lowest: compound 1; then compound 3; then compound 2.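

For the compounds shown here, the first step to touch a substituent rather than a drawn configuration shows that this methyl, on the saturated ring carbon next to the ring atom that bears a large group, has a measurable though limited bearing on the number in this assay: a 2.9-fold higher number from compound 1 to compound 3 (0.47 log units; beyond the scatter). Compound 3 keeps the other ring methyl and the carboxymethyl group, and with hydrogen at this carbon it remains on the same side of compound 2 as compound 1 does, so the methyl is not required for a number well below that of compound 2. Nothing shown here accounts for this step.

The compounds shown leave open whether an ethyl group at this carbon would move the number the other way. They also leave open how compound 3 would respond if its remaining methyl were replaced by hydrogen or drawn with a defined configuration.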